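Terminal ester replacement: from compound 2 to compound 3

The source may hold more compounds than are shown below. What is called first, only, known or untested is meant among the compounds shown, and "the series" means these compounds.

Two members of the series have numbers in a functional assay on B16 cells (Mus musculus) for antiproliferative activity, with a stated time of 72 h; on this read-out higher numbers stand for weaker inhibition and lower numbers for stronger inhibition. Compound 1 `CSc1cnc2ccccc2c1SCC#CCOC(=O)c1ccccc1` gives 17.8 ug/mL in this assay. Compound 2 `O=C(/C=C/c1ccccc1)OCC#CCSc1cnc2ccccc2c1Cl` gives 11.4 ug/mL in this assay, the lowest of the two numbers, yet within the scatter of compound 1, so the two cannot be ordered. Compound 3 `O=C(O)c1ccc(C(=O)OCC#CCSc2cnc3ccccc3c2Cl)cc1` has not yet been measured. It differs from compound 2 in one place: 4-carboxyphenyl in place of 2-phenylethenyl on a carbonyl carbon. Among the measured compounds shown here, no measured step of this kind exists in the set, so the outlook rests on the change alone. A modest step toward weaker inhibition, near the edge of the scatter, is expected, a 2.2-fold higher number from compound 2 to compound 3 (0.34 log units; beyond the scatter). Compound 3 is estimated at 25 ug/mL, with a range from 9 ug/mL to 70 ug/mL.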

Compound 3, concentration for 50% inhibition: 53.8 ug/mL
Beside the measured number, compound 3's estimate is 2.2-fold (0.33 log units) below it; the measured number falls inside the stated range.
By their numbers in this assay, from the lowest: compounds 2 and 1 (each within the scatter of the next); then compound 3.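

On the carbonyl carbon, 4-carboxyphenyl in place of 2-phenylethenyl gives a step beyond the scatter in this assay: a 4.7-fold higher number from compound 2 to compound 3 (0.67 log units; beyond the scatter). This position therefore responds to the group it carries, at least for this pair, where the entering group brings a hydrogen-bond donor and acceptor that the leaving group lacks. No measurement shown here bears on the reason for this step.

Still open, on these data alone, is whether the step follows the carboxylic acid or the replacement of the ethenyl link by a directly attached ring. A plain phenyl or a methyl ester in the same place would separate these two readings.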